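Isopropoxy for pyridin-2-yl on the shared core

The source may report more compounds than this note shows. Statements on the series, on what has been measured and on what is new or still open speak of the compounds shown alone.

In a functional assay on A549 cells (Homo sapiens) for inhibition, read by MTT assay, with a stated time of 72 h (a lower number here means a stronger inhibitor, a higher number a weaker inhibitor), compound 1 `COc1ccc(-c2cc(C(=O)N3CCC4(CC3)CC(=O)c3nn(C(C)(C)C)cc3O4)c3ccccc3n2)cc1` gives 3740 nM while compound 2 `CC(C)(C)n1cc2c(n1)C(=O)CC1(CCN(C(=O)c3cc(-c4ccccn4)nc4ccccc34)CC1)O2` gives 7720 nM and compound 3 `CC(C)(C)n1cc2c(n1)C(=O)CC1(CCN(C(=O)c3cc(Cl)nc4ccccc34)CC1)O2` gives 7170 nM on the same read-out. Compound 2 sits at the high end of this narrow range, though its nearest neighbour is not separated from it (a 1.1-fold lower number from compound 2 to compound 3 (0.03 log units; within the scatter)), and only its furthest neighbour stands apart (a 2.1-fold higher number from compound 1 to compound 2 (0.31 log units; beyond the scatter)).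

Compound 4 `CC(C)Oc1cc(C(=O)N2CCC3(CC2)CC(=O)c2nn(C(C)(C)C)cc2O3)c2ccccc2n1` has not yet been measured. It carries isopropoxy in place of pyridin-2-yl on an aromatic carbon next to the ring nitrogen, a difference counted as isopropoxy in place of pyridin-2-yl on an aromatic carbon in this comparison.

All three measured steps change this same place. The largest is the modest one already given, and the swap to chloro from 4-methoxyphenyl stays within the scatter (a 1.9-fold higher number from compound 1 to compound 3 (0.28 log units; within the scatter)). Going by the values given here, no measured compound carries an alkoxy group directly on this carbon, so the evidence is indirect. Three quite different groups have so far moved the number very little, so only a small change is expected here, with the step estimated as a 1.4-fold lower number from compound 2 to compound 4 (0.15 log units; within the scatter) and not expected to exceed the scatter. For compound 4 an estimated 5500 nM is expected in this assay and the estimated range runs from 2500 nM to 12000 nM for a single measurement.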

Compound 4, half-maximal inhibitory concentration: > 10000 nM
Compound 4 was reported as a limit; the forecaster's own chance of this, stated with the estimate: 10%; middle value at least 1.8-fold (0.25 log units) away from the limit.
By their numbers in this assay, from the lowest: compounds 1, 3 and 2 (each within the scatter of the next, the first and the last beyond it). At a limit, above all of these: compound 4.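

Compound 4 gives no number here, only a limit of the assay: the limit of > 10000 nM in this assay, at which 1 of the 4 values shown sits. Isopropoxy is the first group in this series joined to this aromatic carbon through oxygen, and it gives no sign of a stronger inhibitor than the aryl groups or chloro: against the 4-methoxyphenyl of compound 1 the change is beyond the scatter even at its floor (an at least 2.6-fold higher number from compound 1 to compound 4 (0.42 log units; beyond the scatter)). Against pyridin-2-yl (an at least 1.2-fold higher number from compound 2 to compound 4 (0.11 log units; that floor lies within the scatter)) and chloro (an at least 1.3-fold higher number from compound 3 to compound 4 (0.14 log units; that floor lies within the scatter)), only floors within the scatter can be read, so these two steps may be small or much larger, and this assay does not separate them from the scatter.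

Going by these compounds, how far compound 4 lies beyond its limit stays open, and with it the true size of all three steps. Also open, on these data alone, is whether a smaller methoxy, a longer alkoxy chain or an amine such as morpholine on this same carbon would give a measurable number, and so whether the oxygen link or the isopropyl group itself goes with this result.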